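Moving the methoxy group: compound 2 to compound 3

The source may hold more compounds than are shown below. What is called first, only, known or untested is meant among the compounds shown, and "the series" means these compounds.

In a functional assay on U-373MG ATCC cells (Homo sapiens) for inhibition, read by MTT assay, with a stated time of 72 h (on this read-out lower numbers stand for stronger inhibition and higher numbers for weaker inhibition), two compounds with a shared core have been measured so far. Compound 1 `COc1ccc(NC(=S)NC2CC(C)(C)Oc3ccc(Br)cc32)cc1` gives 40000 nM, and compound 2 `COc1ccccc1NC(=S)NC1CC(C)(C)Oc2ccc(Br)cc21` gives 22000 nM. These two numbers lie within the scatter of each other, so neither compound can be said to stand apart. The next compound is compound 3 `COc1cccc(NC(=S)NC2CC(C)(C)Oc3ccc(Br)cc32)c1`, which has the same atoms as compound 2, joined differently: 3-methoxyphenyl in place of 2-methoxyphenyl on an amide-type nitrogen. Among the measured compounds shown here, one measured step bears on this change, namely 2-methoxyphenyl in place of 4-methoxyphenyl on that same kind of nitrogen, and it amounts to a 1.8-fold lower number from compound 1 to compound 2 (0.26 log units; within the scatter). For the measured compounds named here, no measurement yet covers the 3-methoxyphenyl group itself, and a single step is thin evidence. Even so, nothing measured points to a real difference, so no step beyond the scatter is expected in this assay. The expected step is a 1.4-fold higher number from compound 2 to compound 3 (0.13 log units; within the scatter). For compound 3 the estimate is 30000 nM, with an expected range from 14000 nM to 60000 nM.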

Compound 3, half-maximal inhibitory concentration: 66000 nM
Estimate against measurement, compound 3: 2.2-fold (0.34 log units) below, outside the stated range (above it).
By their numbers in this assay, from the lowest: compounds 2, 1 and 3 (each within the scatter of the next, the first and the last beyond it).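

In this assay, among the compounds shown here, moving the methoxy group can change the result, though the effect is modest: 3-methoxyphenyl in place of 2-methoxyphenyl on the amide-type nitrogen gives a 3.0-fold higher number from compound 2 to compound 3 (0.48 log units; beyond the scatter), the first step in this small set to lie beyond the scatter. The comparison with the third placement stays unresolved, since 3-methoxyphenyl in place of 4-methoxyphenyl gives a 1.7-fold higher number from compound 1 to compound 3 (0.22 log units; within the scatter), so compound 1 cannot be separated from compound 3 any more than from compound 2. The two groups that do separate have the same atoms and the same counts of donors and acceptors, so a difference in how the atoms are joined is enough to produce a measurable step here, and nothing available offers an explanation for it.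

The compounds shown leave open whether this difference belongs to the methoxy group alone or would also appear with another group at this place on the nitrogen, such as an ethoxy group, a hydroxyl or a chlorine atom. They also leave open whether the same placements would separate in the same way if a carbonyl stood in place of the thiocarbonyl.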